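A few compounds are considered here, and "the series" means these few. Any claim that something is new, unique, unknown or untested is made for them only; others in the source may bear on it.

Compound 1 `CN(C)CCn1cnnc1-c1cc(Oc2ccc(NC(=O)N/N=C/c3ccc(Cl)cc3Cl)cc2F)ccn1` is the anchor of this set. In a functional assay on U-87MG ATCC cells (Homo sapiens) for cytotoxicity, read by MTT assay, with a stated time of 72 h (on this read-out lower numbers stand for stronger inhibition and higher numbers for weaker inhibition), compound 1 gives 2330 nM, the lowest number among the three measured compounds, which on this read-out means the strongest inhibition. Its two neighbours keep the shared core and differ only in the aromatic ring on the carbon with a double bond to nitrogen. Compound 2 `COc1ccc(OC)c(/C=N/NC(=O)Nc2ccc(Oc3ccnc(-c4nncn4CCN(C)C)c3)c(F)c2)c1` gives 6400 nM, and compound 3 `CN(C)CCn1cnnc1-c1cc(Oc2ccc(NC(=O)N/N=C/c3cccc(Cl)c3Cl)cc2F)ccn1` gives 13200 nM. Both swaps weaken the cytotoxic effect: a 2.7-fold higher number from compound 1 to compound 2 (0.44 log units; beyond the scatter) and a 5.7-fold higher number from compound 1 to compound 3 (0.75 log units; beyond the scatter), with a 2.1-fold higher number from compound 2 to compound 3 (0.31 log units; beyond the scatter) separating the two.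

Compound 4 `COc1ccc(/C=N/NC(=O)Nc2ccc(Oc3ccnc(-c4nncn4CCN(C)C)c3)c(F)c2)cc1O` makes a change of the same kind at the same position: 3-hydroxy-4-methoxyphenyl in place of 2,4-dichlorophenyl on a carbon with a double bond to nitrogen

The two measured steps away from compound 1 both point the same way, each modest and beyond the scatter. Replacing the 2,4-dichlorophenyl with a ring carrying oxygen substituents, as in compound 2, costs potency, so the number for compound 4 is expected to rise by a similar modest step, a 3.0-fold higher number from compound 1 to compound 4 (0.48 log units; beyond the scatter). Compound 4 is therefore estimated at 7000 nM, within a range of 3000 nM to 16000 nM.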

Compound 4, half-maximal inhibitory concentration: > 100000 nM
Compound 4: only a limit was reported; the forecaster's own chance of this, stated with the estimate: 5%; at least 14-fold (1.15 log units) between middle value and limit.
By their numbers in this assay, from the lowest: compound 1; then compound 2; then compound 3. At a limit, above all of these: compound 4.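

Compound 4 gives only a limit in this assay, not a number: the limit of > 100000 nM in this assay, at which 1 of the 4 values shown sits. Placing 3-hydroxy-4-methoxyphenyl on the carbon with a double bond to nitrogen gives an at least 42-fold higher number from compound 1 to compound 4 (1.63 log units; beyond the scatter), so this position can tolerate far more than the modest shifts seen so far, or far less, depending on the ring. Oxygen on the ring does not alone predict the outcome: the change gives an at least 15-fold higher number from compound 2 to compound 4 (1.19 log units; beyond the scatter), even though 2,5-dimethoxyphenyl also carries oxygen, and it gives an at least 7.5-fold higher number from compound 3 to compound 4 (0.87 log units; beyond the scatter).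

The compounds shown do not separate the hydroxy from the methoxy in this loss, and the real number for compound 4 remains unknown. From the compounds shown here alone, it also remains open how a ring carrying an amine or a carboxylic acid at this position would behave.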